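This account rests on a few compounds, and the source may have more. Where it says the series, first, only, none or still open, it means among the compounds named here.

Compound 1 `Cc1c(C(=O)N=[N+]=[N-])[n+]([O-])c2cc(Cl)ccc2[n+]1[O-]` gives 99.3% in a functional assay on Ehrlich cells (Mus musculus) for cytotoxicity, read by trypan blue exclusion, with a stated time of 2 h, tested at 1 ug/mL; a higher number here means a weaker effect of the compound at the concentration tested, a lower number a stronger effect.
Compound 2 `COc1ccc2c(c1)[n+]([O-])c(C(=O)N=[N+]=[N-])c(C)[n+]2[O-]` gives 94.5% in this assay.

The account follows the step from compound 1 to compound 3 `Cc1c(NC(=O)OC(C)C)[n+]([O-])c2cc(Cl)ccc2[n+]1[O-]`. Among the two compounds measured, compound 1 is the reference point: the step of a number 4.8 percentage points lower from compound 1 to compound 2 (within the scatter) lies within the scatter, so the two numbers read alike, and both sit where a compound has almost no effect at the concentration tested.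

The change from compound 1 to compound 3 is a group of 7 heavy atoms (4 carbon, 1 nitrogen, 2 oxygen; no ring) in place of a group of 5 heavy atoms (1 carbon, 3 nitrogen, 1 oxygen; no ring), on an aromatic carbon. For the measured compounds named here, the only measured step concerns a different change, methoxy in place of chloro on an aromatic carbon, and that step was within the scatter. Going by the values given here, no measured step touches the group that leaves or the (isopropoxycarbonyl)amino group that enters, so nothing measured speaks for a shift in either direction. With both measured numbers near the top of the scale, the expectation for compound 3 is a number in the same region, with the step of a number 4.3 percentage points lower from compound 1 to compound 3 (within the scatter) expected to stay within the scatter. Compound 3 is therefore estimated at 95%, in a range from 82% to 100%.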

Compound 3, a percentage reported as activity, at one concentration (the size of the read-out at that concentration, not a potency): 100%
The estimate for compound 3 lay 5 percentage points below the measured number, within the range that was stated.
By their numbers in this assay, from the lowest: compounds 2, 1 and 3 (each within the scatter of the next).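

For the compounds shown here, the earlier pair changed methoxy for chloro on an aromatic carbon, whereas compound 3 is the first to alter the group on the aromatic carbon next to the ring nitrogen, and in this assay putting (isopropoxycarbonyl)amino in place of the group of 5 heavy atoms gives a number 0.7 percentage points higher from compound 1 to compound 3 (within the scatter). This is a large exchange, with a group bearing a hydrogen-bond donor replacing one without, yet it does not separate the two compounds, and compound 3, at 100%, remains where a compound has almost no effect at the concentration tested. No measurement shown here bears on why this exchange leaves the read-out within the scatter.

With all three numbers near the top of the scale, the compounds shown cannot tell whether this position matters for the effect on these cells at all, since no group here gives a clear effect at this concentration. Going by these compounds, it remains open whether a free amine or a carboxylic acid at this position, or a longer chain in place of the isopropyl part of the carbamate, would give a number clearly lower than that of compound 1.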